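The compounds below may be only part of what the source reports. "The series", "measured", "known", "first", "only" and "open" are said of these compounds alone.

In a functional assay on HepG2 cells (Homo sapiens) for cytotoxicity, read by MTT assay, with a stated time of 48 h (a higher number here means a weaker inhibitor, a lower number a stronger inhibitor), compound 1 `Cc1ccccc1-c1nnc(SCCn2c([N+](=O)[O-])cnc2C)o1` gives 5100 nM, compound 2 `Cc1ccc(-c2nnc(SCCn3c([N+](=O)[O-])cnc3C)o2)cc1` gives 2200 nM, and compound 3 `Cc1ncc([N+](=O)[O-])n1CCSc1nnc(-c2ccc([N+](=O)[O-])cc2)o1` gives 4100 nM. Compound 3 lies within the scatter of both other compounds. Compound 4 `Cc1ncc([N+](=O)[O-])n1CCSc1nnc(-c2ccc(F)cc2)o1` follows from compound 3 by fluoro in place of nitro on an aromatic carbon, with fluoro in place of nitro on an aromatic carbon. The closest measured change is a 1.9-fold higher number from compound 2 to compound 3 (0.27 log units; within the scatter), which also replaces one group on an aromatic carbon. Among the compounds with values here, the only step beyond the scatter is a 2.3-fold lower number from compound 1 to compound 2 (0.37 log units; beyond the scatter), and it is modest. Within the data shown here, no fluoro compound has been measured yet, so no step beyond the scatter is expected in this assay. The estimated change is a 1.4-fold lower number from compound 3 to compound 4 (0.14 log units; within the scatter). For compound 4 the expected value is 3000 nM, with an estimated range of 1300 nM to 7000 nM.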

Compound 4, half-maximal inhibitory concentration: 600 nM
Beside the measured number, compound 4's estimate is 5.0-fold (0.70 log units) above it; the whole stated range lies above it.
By their numbers in this assay, from the lowest: compound 4; then compounds 2, 3 and 1 (each within the scatter of the next, the first and the last beyond it).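

In this assay the position para to a large group can carry a change well beyond the scatter: fluoro in place of nitro (a 6.8-fold lower number from compound 3 to compound 4 (0.83 log units; beyond the scatter)), where the earlier nitro in place of methyl stayed within it. Fluoro also stands apart from methyl at this position (a 3.7-fold lower number from compound 2 to compound 4 (0.56 log units; beyond the scatter)). The 4-fluorophenyl compound likewise separates from the 2-methylphenyl one (an 8.5-fold lower number from compound 1 to compound 4 (0.93 log units; beyond the scatter)), though that step also moves the group.

From the compounds shown here alone, how chloro, an amine or a carboxylic acid would read at this position remains open. Nothing measured here bears on why fluoro gives the lower number.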